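The source may report more compounds than this note shows. Statements on the series, on what has been measured and on what is new or still open speak of the compounds shown alone.

Measured compounds:
compound 1 `CNc1nc(NCc2ccc(S(C)(=O)=O)cc2)cc(-c2ccccn2)n1` — 36 nM
compound 2 `CNc1nc(NC2(c3ccc(Cl)cc3)CCC2)cc(-c2ccccn2)n1` — 25 nM

In a functional assay on HEK293 cells for agonist activity at G-protein coupled receptor 39 (Homo sapiens), read by inositol phosphate accumulation (on this read-out lower numbers stand for an effect already at smaller amounts and higher numbers for an effect only at larger amounts of compound), compound 1 gives 36 nM, the higher of the two numbers; the nearest neighbour is compound 2, whose value lies within the usual scatter, so the two cannot be told apart. Compound 3 `CNc1nc(NCc2ccc(OC(F)(F)F)cc2)cc(-c2ccccn2)n1` has not yet been measured. It differs from compound 1 by trifluoromethoxy in place of methylsulfonyl on an aromatic carbon. Among the measured compounds shown here, no measured pair shows this exchange, so nothing here sets its size. The step from compound 1 to compound 3 is expected to be small, a 1.4-fold higher number from compound 1 to compound 3 (0.14 log units; within the scatter), not clearly beyond the scatter in either direction. Compound 3 is therefore estimated at 50 nM, with a likely range from 15 nM to 170 nM.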

Compound 3, half-maximal effective concentration: 13 nM
The estimate for compound 3 lay 3.8-fold (0.59 log units) above the measured number, and the stated range ends above it.
By their numbers in this assay, from the lowest: compounds 3, 2 and 1 (each within the scatter of the next, the first and the last beyond it).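

In this assay, trifluoromethoxy in place of methylsulfonyl on this aromatic carbon gives a 2.8-fold lower number from compound 1 to compound 3 (0.44 log units; beyond the scatter), a modest step. Among the compounds shown here, this is the first sign that the group at this position affects the read-out, and it shows that methylsulfonyl is not required there for activity. Nothing available explains the step. Going by these compounds, how an amine, a nitrile or a carboxylic acid at this carbon would compare remains open. So does whether the same exchange would give a similar step on a different core.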